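The source may hold more compounds than are shown below. What is called first, only, known or untested is meant among the compounds shown, and "the series" means these compounds.

Measured so far in an in vitro functional assay on HEK285-7 cells for antagonist activity at prostaglandin D2 receptor 2 (Homo sapiens), read by BRET and beta-arrestin recruitment; a higher number here means a weaker inhibitor, a lower number a stronger inhibitor:

compound 1, `Nc1nc(-c2ccc(Cl)cc2)c(CC(=O)O)s1`: > 100000 nM
compound 2, `O=C(O)Cc1sc(C(c2ccccc2)c2ccccc2)nc1-c1ccc(F)c(F)c1`: 43 nM
compound 3, `O=C(O)Cc1sc(C(c2ccc(F)cc2)c2ccc(F)cc2)nc1-c1cccc(F)c1`: 18 nM

The value of compound 1 is a limit of this assay and not a number; compound 1 sits at the limit of > 100000 nM in this assay, at which 1 of the 3 values shown sits. Of the two numbers shown, compound 3 has the lowest; its nearest neighbour, compound 2, shows a number 43 nM, while compound 3 shows 18 nM, a gap that lies beyond the usual scatter. Both numbered compounds carry the shared core of compound 3 with a diarylmethyl group and an acid chain in place.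

Compound 4, `Cc1cc(-c2nc(C(c3ccc(F)cc3)c3ccc(F)cc3)sc2CC(=O)O)ccn1`, has not yet been measured in this assay. It differs from compound 3 in one place: 2-methylpyridin-4-yl in place of 3-fluorophenyl on an aromatic carbon. The group that enters carries one hydrogen-bond acceptor where the group that leaves carries none; the heavy-atom count is unchanged. Among the compounds with values here, there is no measured pair in this set that shows what such a swap does, so the expectation rests on compound 3 alone. A modest loss is expected, as the step of a 2.2-fold higher number from compound 3 to compound 4 (0.35 log units; beyond the scatter), not far beyond the scatter. Compound 4 is therefore estimated at 40 nM, with a range from 12 nM to 130 nM.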

Compound 4, half-maximal inhibitory concentration: 53 nM
For compound 4 the middle estimate is 1.3-fold (0.12 log units) below the measured one; the measured number falls inside the stated range.
By their numbers in this assay, from the lowest: compound 3; then compounds 2 and 4 (each within the scatter of the next). At a limit, above all of these: compound 1.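

In this assay, 2-methylpyridin-4-yl in place of 3-fluorophenyl gives a 2.9-fold higher number from compound 3 to compound 4 (0.47 log units; beyond the scatter) and is the only one-place step shown in the series. The position, an aromatic carbon next to the ring nitrogen and next to the ring atom that bears a carboxymethyl group, therefore accepts a six-membered aromatic ring with 1 hetero atom at a modest cost, and compound 4 still reads 53 nM. The heavy-atom count stays the same, but the swap changes the ring atoms and the substituent together, and nothing measured here gives a reason for the step.

Within the data shown here, the single step cannot separate the contribution of the ring nitrogen from that of the methyl group, and a plain pyridin-4-yl or a 2-aminopyridin-4-yl would be needed to tell them apart. From the compounds shown here alone, it also remains open whether the same swap costs a similar amount alongside the unsubstituted diphenylmethyl group of compound 2, rather than the bis(4-fluorophenyl)methyl group shared by the pair.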